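Compound 3 to compound 4: exchange on the carbonyl carbon

A few compounds are considered here, and "the series" means these few. Any claim that something is new, unique, unknown or untested is made for them only; others in the source may bear on it.

In a functional assay on HeLa cells (Homo sapiens) for antiproliferative activity, read by MTT assay, with a stated time of 72 h (a lower number here means a stronger inhibitor, a higher number a weaker inhibitor), compound 3 `C=CC(=O)Nc1cccc(Oc2nc(Nc3ccc(OC)nc3)nc3c2CSCC3)c1` gives 26300 nM, within the scatter of compound 1 `C=CC(=O)Nc1cccc(Oc2nc(Nc3cccc(OC)c3)nc3c2CSCC3)c1` at 28900 nM and of compound 2 `COc1cccc(Nc2nc3c(c(Oc4cccc(NC(=O)C=C(C)C)c4)n2)CSCC3)c1` at 19100 nM. Compound 4 `COc1ccc(Nc2nc3c(c(Oc4cccc(NC(=O)C=C(C)C)c4)n2)CSCC3)cn1` carries one change from compound 3: 2-methylprop-1-en-1-yl in place of vinyl on a carbonyl carbon. The same exchange has been measured once, as a 1.5-fold lower number from compound 1 to compound 2 (0.18 log units; within the scatter). The other measured step, a 1.1-fold lower number from compound 1 to compound 3 (0.04 log units; within the scatter), introduces the 6-methoxypyridin-3-yl group that compound 3 and compound 4 share. In this assay no step beyond the scatter is therefore expected, and the estimated step is a 1.4-fold lower number from compound 3 to compound 4 (0.14 log units; within the scatter). Compound 4 is expected at 19000 nM, with an estimated range of 11000 nM to 33000 nM.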

Compound 4, half-maximal inhibitory concentration: 29200 nM
Estimate against measurement, compound 4: 1.5-fold (0.19 log units) below; low and high end bracket the measured number.
By their numbers in this assay, from the lowest: compounds 2, 3, 1 and 4 (each within the scatter of the next).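

On a carbonyl carbon, the exchange of vinyl for 2-methylprop-1-en-1-yl can now be read on a second core, with a 1.1-fold higher number from compound 3 to compound 4 (0.05 log units; within the scatter), and the two readings agree: the same change on two cores in this assay, a 1.5-fold lower number (0.18 log units; within the scatter) from compound 1 to compound 2 and a 1.1-fold higher number (0.05 log units; within the scatter) from compound 3 to compound 4, 1.7-fold (0.23 log units) apart, within the scatter of two such steps
The 6-methoxypyridin-3-yl exchange can likewise be read with both groups on the carbonyl carbon, with a 1.5-fold higher number from compound 2 to compound 4 (0.18 log units; within the scatter): the same change on two cores in this assay, a 1.1-fold lower number (0.04 log units; within the scatter) from compound 1 to compound 3 and a 1.5-fold higher number (0.18 log units; within the scatter) from compound 2 to compound 4, 1.7-fold (0.23 log units) apart, within the scatter of two such steps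
In this assay, neither exchange gives a step beyond the scatter on either core.

Open, as far as these compounds go, is whether an ethyl group or a longer chain ending in a dimethylamino group on this carbonyl carbon would give a step beyond the scatter.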